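Swapping the pyridine attachment point on a weak HepG2 inhibitor

The compounds below may be only part of what the source reports. "The series", "measured", "known", "first", "only" and "open" are said of these compounds alone.

Measured so far:
- Compound 1, `O=C(NCc1ccc(F)cc1)c1cc(Oc2ccc(/C=C/c3ccccn3)cc2)ccn1`: 45100 nM
- Compound 2, `CC(C)NC(=O)c1cc(Oc2ccc(/C=C/c3ccccn3)cc2)ccn1`: > 100000 nM
- Compound 3, `O=C(NC1CCCCC1)c1cc(Oc2ccc(/C=C/c3ccccn3)cc2)ccn1`: 20600 nM

In a functional assay on HepG2 cells (Homo sapiens) for antiproliferative activity, read by CCK-8 assay, with a stated time of 48 h (a lower number here means a stronger inhibitor, a higher number a weaker inhibitor), compound 3 gives 20600 nM, the lowest of the two numbers shown. The nearest is compound 1, and a 2.2-fold lower number from compound 1 to compound 3 (0.34 log units; beyond the scatter). Compound 2 gives only a limit of the assay, (the limit of > 100000 nM in this assay, at which 1 of the 3 values shown sits).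

All three measured steps change the group on the amide-type nitrogen, as in an at least 2.2-fold higher number from compound 1 to compound 2 (0.34 log units; beyond the scatter) and an at least 4.8-fold lower number from compound 2 to compound 3 (0.68 log units; beyond the scatter). Compound 4, `O=C(NC1CCCCC1)c1cc(Oc2ccc(/C=C/c3ccncc3)cc2)ccn1`, instead changes the other end of the molecule: pyridin-4-yl in place of pyridin-2-yl on a double-bonded chain carbon bound to a double-bonded chain carbon. Among the measured compounds shown here, no measured step touches that part, so nothing here says whether this change helps or hurts; it is a rearrangement of the same atoms. The expectation is therefore a step of about a 1.1-fold higher number from compound 3 to compound 4 (0.03 log units; within the scatter), within the scatter, and compound 4 is estimated at 22000 nM, between 7000 nM and 70000 nM.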

Compound 4, half-maximal inhibitory concentration: 22400 nM
Compound 4: the middle estimate sits 1.0-fold (0.01 log units) below what was measured; low and high end bracket the measured number.
By their numbers in this assay, from the lowest: compounds 3, 4 and 1 (each within the scatter of the next, the first and the last beyond it). At a limit, above all of these: compound 2.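

Among the compounds shown here, this is the first view of the far end of the molecule: in this assay, pyridin-4-yl in place of pyridin-2-yl gives a 1.1-fold higher number from compound 3 to compound 4 (0.04 log units; within the scatter). At this position, the two attachment points cannot be told apart, whereas the changes on the amide-type nitrogen gave steps beyond the scatter. Nothing measured here offers a reason for this result.

Pyridin-3-yl and a plain phenyl ring at this place remain open. So does whether the same swap behaves alike with 4-fluorobenzyl instead of cyclohexyl on the amide-type nitrogen.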